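The source may report more compounds than this note shows. Statements on the series, on what has been measured and on what is new or still open speak of the compounds shown alone.

Compound 1, `COc1ccc2[nH]c3c(c2c1)CCNC31CCN(Cc2ccc(Br)c(F)c2)CC1`: 1800 nM
Compound 2, `COc1ccc2[nH]c3c(c2c1)CCNC31CCN(Cc2ccc(F)c(Cl)c2F)CC1`: 4500 nM
Compound 3, `COc1ccc2[nH]c3c(c2c1)CCNC31CCN(Cc2ccc(F)cc2F)CC1`: 2000 nM

All three were measured in an assay on FRT cells for positive allosteric modulation of Cystic fibrosis transmembrane conductance regulator variant N1303K (Homo sapiens), in the presence of a further agent that is not named here; on this read-out lower numbers stand for an effect already at smaller amounts and higher numbers for an effect only at larger amounts of compound. Compound 1 stands at the lowest number of the three, but its lead is small: the step of a 1.1-fold higher number from compound 1 to compound 3 (0.05 log units; within the scatter) lies within the scatter, while the step of a 2.5-fold higher number from compound 1 to compound 2 (0.40 log units; beyond the scatter) lies beyond it. The shared core is the same throughout; the compounds differ only in the ring carried on the saturated chain carbon bound to the amine nitrogen in a ring.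

Compound 4, `COc1ccc2[nH]c3c(c2c1)CCNC31CCN(Cc2cccnc2)CC1`, changes that ring as well: pyridin-3-yl in place of 4-bromo-3-fluorophenyl on a saturated chain carbon bound to an amine nitrogen in a ring. For the measured compounds named here, the steps that bear on this are the two from compound 1, since each swaps the same group at the same place for another ring; one gave no change beyond the scatter, the other a modest rise. Taking away a single chloro gave a 2.3-fold lower number from compound 2 to compound 3 (0.35 log units; beyond the scatter). Going by the values given here, no measured step puts a ring with a nitrogen at this place, so the expectation is loose. Compound 4 is expected to give 3500 nM in this assay, within a range of 1200 nM to 10000 nM. That estimate means a step of a 1.9-fold higher number from compound 1 to compound 4 (0.29 log units; within the scatter), a modest rise in number.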

Compound 4, half-maximal effective concentration: 17000 nM
Compound 4: the middle estimate sits 4.9-fold (0.69 log units) below what was measured; measured number outside the range, above it.
By their numbers in this assay, from the lowest: compounds 1 and 3 (each within the scatter of the next); then compound 2; then compound 4.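

At this place, on a saturated chain carbon bound to an amine nitrogen in a ring, pyridin-3-yl raises the number in this assay more than any change among the earlier rings, with steps of a 9.4-fold higher number from compound 1 to compound 4 (0.98 log units; beyond the scatter) and an 8.5-fold higher number from compound 3 to compound 4 (0.93 log units; beyond the scatter) and also a 3.8-fold higher number from compound 2 to compound 4 (0.58 log units; beyond the scatter). The position therefore does not accept every six-membered aromatic ring equally: the three halogen-bearing phenyl rings stay closer together, and the ring with a nitrogen and no halogen stands apart from all of them. Nothing available explains this rise.

This change removes the halogens and brings in the ring nitrogen at once, so the compounds shown cannot separate the two. A plain phenyl ring, or a pyridine ring carrying a fluoro or chloro group, would be needed to tell which of them goes with the higher number.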